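The compounds below may be only part of what the source reports. "The series", "measured", "known", "first", "only" and "open" are said of these compounds alone.

Measured so far in an assay on isolated protein for agonist activity at Bile acid receptor (Homo sapiens), read by AlphaScreen, with a stated time of 30 min; a lower number here means that less compound is needed, a higher number that more compound is needed for the effect:
- compound 1 `COC(=O)c1cccc(-c2ccc([C@H]3S[C@@H](C)C(=O)Nc4c3c(C)nn4-c3ccccc3C)cc2)c1`: "not active" (no number reported)
- compound 2 `COc1ccc(Oc2ccc([C@H]3S[C@@H](C)C(=O)Nc4c3c(C)nn4-c3ccccc3C)cc2)cc1`: 2200 nM
- compound 3 `CCOc1cccc(-c2ccc([C@H]3S[C@@H](C)C(=O)Nc4c3c(C)nn4-c3ccccc3C)cc2)c1`: 3500 nM

Compound 1 gives no number in this assay, only the report of no activity. Compound 3 stands together with compound 2: the step of a 1.6-fold higher number from compound 2 to compound 3 (0.20 log units; within the scatter) separates them by no more than the scatter, so the two numbers are not distinguished, and no further number is available in the series.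

Compound 4 `Cc1ccccc1-n1nc(C)c2c1NC(=O)[C@H](C)S[C@@H]2c1ccc(/C=C/c2ccccc2)cc1` follows from compound 3 by 2-phenylethenyl in place of 3-ethoxyphenyl on an aromatic carbon. Among the compounds with values here, the one measured step, a 1.6-fold higher number from compound 2 to compound 3 (0.20 log units; within the scatter), exchanges one oxygen-bearing aryl group for another at the same aromatic carbon and stays within the scatter; it is the only step that bears on this change, and it does not cover the loss of the hydrogen-bond acceptor or the entry of the double bond outside aromatic rings. Compound 1 shows that a different group at this position can remove activity altogether, which keeps the uncertainty wide. The expected step is no change at the digits printed from compound 3 to compound 4 (within the scatter), estimated to remain within the scatter. For compound 4 the expected value in this assay is 3500 nM, with a range from 1000 nM to 12000 nM.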

Compound 4, half-maximal effective concentration: "not active" (no number reported)
The entry for compound 4 holds no number; there is nothing to compare the estimate with.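

Within the data shown here, with compound 4 reported as "not active" (no number reported) in this assay no step from compound 3 to compound 4 can be read. The compounds shown leave open how far compound 1 and compound 4 lie from compound 2 and compound 3 on a numerical scale. No measured evidence bears on this result.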